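A few compounds are considered here, and "the series" means these few. Any claim that something is new, unique, unknown or untested is made for them only; others in the source may bear on it.

Working notes on the series in an assay on CHO cells for displacement of a labelled ligand from prostaglandin D2 receptor 2 (Homo sapiens), read by scintillation counting; a lower number here means a stronger inhibitor, a higher number a weaker inhibitor.

Of the compounds shown here, three have numbers so far. Compound 1 `CS(=O)(=O)c1ccc(F)c(C#Cc2cc(Cl)ccc2OCC(=O)O)c1` gives 3.3 nM. Compound 3 `CS(=O)(=O)c1ccc(Cl)c(C#Cc2cc(Cl)ccc2OCC(=O)O)c1` gives 3.5 nM, and compound 2 `CC(C)c1ccc(S(C)(=O)=O)cc1C#Cc1cc(C#N)ccc1OCC(=O)O` gives 12 nM. Compound 3 thus stands second highest of the three numbers; its nearest neighbour is compound 1, with which it lies within the scatter, and its furthest is compound 2, which stands beyond the scatter from it. Among the measured compounds shown here, the one single-point step measured, a 1.1-fold higher number from compound 1 to compound 3 (0.03 log units; within the scatter), shows chloro in place of fluoro on an aromatic carbon leaving the number essentially unchanged.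

Compound 4 `CC(C)c1ccc(S(C)(=O)=O)cc1C#Cc1cc(Cl)ccc1OCC(=O)O` is not yet measured. Relative to compound 3 the change is isopropyl in place of chloro on an aromatic carbon, on an aromatic carbon of the six-membered carbon ring, ortho to a large group and para to a methylsulfonyl group. For the measured compounds named here, no measured step bears on this exact change: compound 2 also carries isopropyl at that place but differs from compound 4 in a second place as well, so only the two values can be compared, with compound 2 at 12 nM and compound 3 at 3.5 nM. The step of a 1.1-fold higher number from compound 1 to compound 3 (0.03 log units; within the scatter) at the same carbon was within the scatter. The step of a 1.4-fold higher number from compound 3 to compound 4 (0.15 log units; within the scatter) is therefore expected to be small, with no strong direction. Compound 4 is estimated at 5 nM, in the range 1.5 nM to 15 nM.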

Compound 4, inhibition constant: 4.6 nM
Compound 4: middle estimate off by 1.1-fold (0.04 log units), on the high side; the measured number falls inside the stated range.
By their numbers in this assay, from the lowest: compounds 1, 3 and 4 (each within the scatter of the next); then compound 2.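

At the carbon ortho to a large group and para to a methylsulfonyl group, isopropyl now joins chloro and fluoro: in this assay the readings (a 1.3-fold higher number from compound 3 to compound 4 (0.12 log units; within the scatter)) and (a 1.4-fold higher number from compound 1 to compound 4 (0.14 log units; within the scatter)) both lie within the scatter, so the number does not separate the three groups even though isopropyl brings 3 heavy atoms where chloro brings 1. Among the compounds shown here, the second varied place gives the first single-point reading beyond the scatter, a modest one, with chloro in place of cyano (a 2.6-fold lower number from compound 2 to compound 4 (0.42 log units; beyond the scatter)), so the difference between the two isopropyl compounds belongs to that place and not to the isopropyl group. No measurement available here bears on the reason for either result.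

From the compounds shown here alone, whether the flat response at the first carbon extends to an amine, a carboxylic acid or a longer alkyl chain stays open from these compounds. Going by these compounds, it also stays open whether the change from cyano to chloro gives a step of similar size when fluoro or chloro replaces isopropyl.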